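The compounds below may be only part of what the source reports. "The series", "measured", "known", "first", "only" and "open" are said of these compounds alone.

Values so far in an ADME assay on Vero cells (Chlorocebus sabaeus) for cytotoxicity, read by CellTiter-Glo, with a stated time of 72 h; a higher number here means that more compound is tolerated, a lower number that less compound is tolerated
Compound 1 `CCNc1n[n+]([O-])c2ccccc2[n+]1[O-]` gives 17 ug/mL
Compound 2 `[O-][n+]1nc(NC2CC2)[n+]([O-])c2ccccc21` gives 21 ug/mL
Compound 3 `CC(C)(C)Nc1n[n+]([O-])c2ccccc2[n+]1[O-]` gives 8 ug/mL

Compound 3 (8 ug/mL) stands lowest of the three in this assay, and its gaps to both others lie beyond the scatter. Compound 4 `[O-][n+]1nc(NC2CCC2)[n+]([O-])c2ccccc21` has not yet been measured. It differs from compound 3 by a single change, cyclobutyl in place of tert-butyl on a nitrogen on an aromatic ring, and the count reads cyclobutyl in place of tert-butyl on a nitrogen on an aromatic ring in full.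

For the measured compounds named here, no measured compound carries cyclobutyl, so the case rests on the neighbouring groups. Two modest steps lead to tert-butyl: a 2.1-fold lower number from compound 1 to compound 3 (0.33 log units; beyond the scatter) with ethyl leaving, and a 2.6-fold lower number from compound 2 to compound 3 (0.42 log units; beyond the scatter) with cyclopropyl leaving. The step between those two starting points, a 1.2-fold higher number from compound 1 to compound 2 (0.09 log units; within the scatter) for cyclopropyl in place of ethyl, stays within the scatter.

If cyclobutyl behaves like those two groups, leaving tert-butyl should undo much of that loss, though this is only an expectation drawn from three compounds. The expected change is a 1.9-fold higher number from compound 3 to compound 4 (0.27 log units; within the scatter) in this assay and would be modest, upward and close to the edge of the scatter. For compound 4 the estimated value is 15 ug/mL with an expected range from 8 ug/mL to 26 ug/mL in all.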

Compound 4, half-maximal cytotoxic concentration: 8.9 ug/mL
For compound 4 the middle estimate is 1.7-fold (0.23 log units) above the measured one; low and high end bracket the measured number.
By their numbers in this assay, from the lowest: compounds 3, 4, 1 and 2 (each within the scatter of the next, the first and the last beyond it).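

At this position, on a nitrogen on an aromatic ring, cyclobutyl and tert-butyl carry the same count of carbon atoms, one closed into a ring and one not, and in this assay the exchange gives a 1.1-fold higher number from compound 3 to compound 4 (0.05 log units; within the scatter), so closing the ring leaves no readable mark on the number. A ring alone also does not keep compound 4 with the cyclopropyl compound: the change gives a 2.4-fold lower number from compound 2 to compound 4 (0.37 log units; beyond the scatter), a modest step that shows cyclopropyl and cyclobutyl can be told apart here even though both groups are rings of carbon only. Against ethyl the reading is a 1.9-fold lower number from compound 1 to compound 4 (0.28 log units; within the scatter), so compound 4 cannot be separated from compound 1 and only the gap to compound 2 stands clear.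

Nothing shown here accounts for why these groups fall as they do.

From the compounds shown here alone, whether a larger ring such as cyclopentyl or a longer chain such as n-butyl would stay with compound 3 and compound 4 or move towards compound 2 remains open. Also open, going by these compounds, is how a chain ending in an amine or a carboxylic acid on this nitrogen would read in this assay.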